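The source may hold more compounds than are shown below. What is called first, only, known or untested is meant among the compounds shown, and "the series" means these compounds.

Compound 1 `Cc1ncccc1C#Cc1cc(Cl)ccc1OCC(=O)O` gives 143 nM in an assay on CHO cells for displacement of a labelled ligand from prostaglandin D2 receptor 2 (Homo sapiens), read by scintillation counting; on this read-out lower numbers stand for stronger inhibition and higher numbers for weaker inhibition.
Compound 2 `CN(C)S(=O)(=O)c1cncc(C#Cc2cc(Cl)ccc2OCC(=O)O)c1` gives 37 nM in this assay.

Of the two compounds measured in this assay, compound 2 has the lower number, and the gap to compound 1 is beyond the usual scatter. The two structures differ in more than one place, so their two values alone cannot be assigned to a single change. Compound 3 `Cc1ncc(S(=O)(=O)N(C)C)cc1C#Cc1cc(Cl)ccc1OCC(=O)O` differs from compound 2 in one place only: methyl in place of hydrogen on an aromatic carbon. Within the data shown here, compound 1 carries the same methyl group on its ring, which shows this group does not abolish binding, but no single step in the data isolates its effect. He therefore expects the step from compound 2 to compound 3 to be small, a 1.2-fold lower number from compound 2 to compound 3 (0.09 log units; within the scatter), and not beyond the scatter in either direction. His estimate for compound 3 in this assay is 30 nM, with a range from 10 nM to 100 nM.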

Compound 3, inhibition constant: 41 nM
The estimate for compound 3 lay 1.4-fold (0.14 log units) below the measured number; measured number inside the range.
By their numbers in this assay, from the lowest: compounds 2 and 3 (each within the scatter of the next); then compound 1.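

In this assay, methyl in place of hydrogen on the aromatic carbon next to the ring nitrogen gives a 1.1-fold higher number from compound 2 to compound 3 (0.04 log units; within the scatter) and so leaves binding unchanged within the scatter, which shows that this position, para to a dimethylsulfamoyl group, accepts the methyl group when that group is present. The dimethylsulfamoyl group can now be read as a single change on the methyl-bearing ring, with a 3.5-fold lower number from compound 1 to compound 3 (0.54 log units; beyond the scatter) as a modest step beyond the scatter that the two earlier compounds could not isolate. Nothing measured here speaks to why either step has its size.

The compounds shown leave open whether an ethyl or a methoxy group would be accepted at this position as the methyl group is. They also leave open whether an unsubstituted sulfamoyl group or a carboxylic acid could stand in for the dimethylsulfamoyl group.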